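Replacing the triazole phenyl with hydroxymethyl

This account rests on a few compounds, and the source may have more. Where it says the series, first, only, none or still open, it means among the compounds named here.

Of the compounds shown here, three sharing one core have been tested in an ADME assay on SK-OV-3 cells (Homo sapiens) for cytotoxicity, read by sulforhodamine B assay, with a stated time of 48 h, tested at 10 uM; on this read-out higher numbers stand for more inhibition at the one concentration tested (going by the name of the read-out) and lower numbers for less inhibition. Compound 1, `COc1nc2ccc(Br)cc2cc1C(c1ccccc1)n1cc(-c2ccccc2)nn1`, gives 13.7% in this assay and stands second highest of the three numbers. Compound 3, `COc1nc2ccc(Br)cc2cc1C(c1ccccc1)n1cc(-c2ccc(OC(F)(F)F)cc2)nn1`, gives 14.8%, and the step of a number 1.1 percentage points higher from compound 1 to compound 3 (within the scatter) is within the scatter. For the measured compounds named here, compound 2, `CCCCCCCCc1cn(C(c2ccccc2)c2cc3cc(Br)ccc3nc2OC)nn1`, gives 2.06%, so the step of a number 11.6 percentage points lower from compound 1 to compound 2 (beyond the scatter) is the only change here that moved the number beyond the scatter.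

Compound 4 is `COc1nc2ccc(Br)cc2cc1C(c1ccccc1)n1cc(CO)nn1`. It differs from compound 1 in one place: hydroxymethyl in place of phenyl on an aromatic carbon. Going by the values given here, the step that bears on this is the one from compound 1 to compound 2, where the same phenyl was also replaced, there by octyl, and the number fell by a modest amount. Taking that as the only guide, a drop of similar size is expected, so a number 7.7 percentage points lower from compound 1 to compound 4 (within the scatter) is the estimate. Compound 4 is therefore expected to give about 6% in this assay, with a range from -3% to 16%.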

Compound 4, a percentage reported as inhibition, at one concentration (the size of the read-out at that concentration, not a potency): 3.23%
The estimate for compound 4 lay 2.8 percentage points above the measured number; the measured number falls inside the stated range.
By their numbers in this assay, from the lowest: compounds 2 and 4 (each within the scatter of the next); then compounds 1 and 3 (each within the scatter of the next).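

Hydroxymethyl on this aromatic carbon of the five-membered ring gives in this assay a number 10.5 percentage points lower from compound 1 to compound 4 (beyond the scatter), and likewise a number 11.6 percentage points lower from compound 3 to compound 4 (beyond the scatter), so octyl is no longer the only group without a ring that goes with a lower number here. The two replacements share little beyond lacking a ring: octyl is a long chain, hydroxymethyl is far smaller and carries a hydrogen-bond donor, yet the comparison gives a number 1.2 percentage points higher from compound 2 to compound 4 (within the scatter), so the two cannot be told apart. Across these four compounds, the two with an aromatic ring at this carbon give higher numbers than the two without, and none goes against this.

Nothing available explains this difference. From the compounds shown here alone, whether an amine, a carboxylic acid or a benzyl group at this carbon would fall with the chains or with the aromatic rings stays open.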